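A few compounds are considered here, and "the series" means these few. Any claim that something is new, unique, unknown or untested is made for them only; others in the source may bear on it.

Measured compounds:
Compound 1 `CC[C@@H](C)[C@H](NC(=O)c1ccc(C(CC)(CC)c2ccc(OCC(=O)C(C)(C)C)c(C)c2)n1CC)C(=O)OC` — 590 nM
Compound 2 `CCn1c(C(=O)N(CCC#N)CCC#N)ccc1C(CC)(CC)c1ccc(OCC(O)C(C)(C)C)c(C)c1` — 97 nM

In an assay on HL-60 cells for agonist activity at vitamin D3 receptor (Homo sapiens), read by microscopy, with a stated time of 96 h (a higher number here means that more compound is needed for the effect, a lower number that less compound is needed), compound 1 gives 590 nM, the higher of the two numbers recorded so far. Among the compounds with values here, compound 2 is the only other measured compound; in this assay compound 2 gives 97 nM, and the gap between the two values lies beyond the usual scatter of this measurement. Within the data shown here, compound 2 differs from compound 1 in more than one place, so no single step between them is written down, and only the two values themselves can be compared.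

Compound 3 `CCn1c(C(=O)Nc2ccc(OC(F)(F)F)cc2)ccc1C(CC)(CC)c1ccc(OCC(=O)C(C)(C)C)c(C)c1` has not yet been measured in this assay. It shares the core of compound 1 and differs from it in one place: 4-(trifluoromethoxy)phenyl in place of 1-(methoxycarbonyl)-2-methylbutyl on an amide-type nitrogen. Among the measured compounds shown here, no measured pair isolates this change, so the direction of the step is not known from the data at hand. On the numbers shown, a step of moderate size, downward in value, is expected for compound 3, amounting to a 2.0-fold lower number from compound 1 to compound 3 (0.29 log units; within the scatter), though a step of no real size beyond the scatter would not be surprising. Compound 3 is therefore estimated at 300 nM, with a range from 60 nM to 1500 nM.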

Compound 3, half-maximal effective concentration: > 50000 nM
Compound 3: only a limit was reported; the forecaster's own chance of this, stated with the estimate: 5%; middle value at least 160-fold (2.22 log units) away from the limit.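

In this assay, the amide-type nitrogen proves to be a place where the choice of group matters greatly: putting 4-(trifluoromethoxy)phenyl in place of 1-(methoxycarbonyl)-2-methylbutyl gives an at least 84-fold higher number from compound 1 to compound 3 (1.92 log units; beyond the scatter) on the otherwise shared core. For compound 3, the entry of > 50000 nM is a limit of the assay and not a number. The size of this step is therefore fixed from one side only, and it is the first step among the compounds shown to isolate a change at this nitrogen: the limit of > 50000 nM in this assay, at which 1 of the 3 values shown sits.

The change alters several things at once, since a six-membered aromatic ring enters while the methoxycarbonyl group, the branched chain and both defined stereocentres leave, so the compounds shown cannot separate their contributions. Going by these compounds, it remains open whether an unsubstituted phenyl or a benzyl group on this nitrogen would behave like the 4-(trifluoromethoxy)phenyl group, and whether a carboxylic acid in place of the methyl ester of the 1-(methoxycarbonyl)-2-methylbutyl group would retain the activity of compound 1.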